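Stretching a Chain Toward an Acid on the Shared Core

The source may hold more compounds than are shown below. What is called first, only, known or untested is meant among the compounds shown, and "the series" means these compounds.

The shared core appears in compound 1 `CCOc1ccc2c(=O)c(-c3ccc(O)cc3)coc2c1` and compound 2 `CC(C)Oc1ccc2c(=O)c(-c3ccc(O)cc3)coc2c1`, which differ at a single place. In an assay (Cricetulus griseus) for inhibition of aldehyde dehydrogenase, mitochondrial (Homo sapiens) (on this read-out lower numbers stand for stronger inhibition and higher numbers for weaker inhibition), compound 1 gives 80 nM, and compound 2 gives 80 nM. Within the data shown here, the only measured step, no change at the digits printed from compound 1 to compound 2 (within the scatter), shows no movement; compound 1 stands level with compound 2, and neither can be called the stronger inhibitor.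

Compound 3 `O=C(O)CCCCCCCCCOc1ccc2c(=O)c(-c3ccc(O)cc3)coc2c1` is the unmeasured member. It differs from compound 1 by 7-carboxyheptyl in place of hydrogen on a saturated chain carbon, two bonds along the chain from an oxygen on an aromatic ring. Among the measured compounds shown here, one measured step bears on this, since no change at the digits printed from compound 1 to compound 2 (within the scatter) also places methyl in place of hydrogen on a saturated chain carbon bound to an oxygen on an aromatic ring, and that step was flat. For the measured compounds named here, the 7-carboxyheptyl group of compound 3 goes far beyond a methyl, and no measured step covers a chain of that length or a carboxylic acid. The expected step is a 1.3-fold higher number from compound 1 to compound 3 (0.10 log units; within the scatter), close to no change because no change at the digits printed from compound 1 to compound 2 (within the scatter) showed none. Compound 3 is therefore expected to give 100 nM in this assay, with a range from 30 nM to 400 nM widened by how little the measured data say about such a long chain.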

Compound 3, half-maximal inhibitory concentration: 50 nM
The estimate for compound 3 lay 2.0-fold (0.30 log units) above the measured number; the measured number falls inside the stated range.
By their numbers in this assay, from the lowest: compounds 3, 1 and 2 (each within the scatter of the next).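

Adding 7-carboxyheptyl to compound 1 gives a much larger change than the methyl of compound 2, yet in this assay the result is a 1.6-fold lower number from compound 1 to compound 3 (0.20 log units; within the scatter). The earlier pair showed only that this part of the chain accepts one extra methyl, whereas compound 3 shows that it also accepts a group of 10 heavy atoms with an acid at its far end, with no change beyond the scatter. No measurement of any other kind is available to explain why so large an addition leaves the inhibition within the scatter of compound 1.

The flat result for compound 3 could mean that neither the length of the chain nor the acid matters, or it could mean that two separate effects happen to cancel, and these compounds cannot tell those cases apart. A chain of the same length ending in a methyl, an amine or an ester, together with a shorter chain ending in the same carboxylic acid, would show what each part contributes.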